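From Trifluoromethyl to Chloro: A Small Expected Change

The compounds below may be only part of what the source reports. "The series", "measured", "known", "first", "only" and "open" are said of these compounds alone.

Measured compounds and their values:
Compound 1 `Clc1ccc(CO/N=C/c2c(-c3ccc4ccccc4c3)nc3occn23)cc1Cl` gives 370 nM.
Compound 2 `Clc1ccc(-c2nc3occn3c2/C=N/OCc2ccc(Cl)c(Cl)c2)cc1` gives 410 nM.
Compound 3 `FC(F)(F)c1ccc(CO/N=C/c2c(-c3ccc4ccccc4c3)nc3occn23)cc1` gives 470 nM.

In an assay on HepG2 cells for agonist activity at nuclear receptor subfamily 1 group I member 3 (Homo sapiens), read by a luciferase reporter, with a stated time of 23 h (on this read-out lower numbers stand for an effect already at smaller amounts and higher numbers for an effect only at larger amounts of compound), compound 3 holds the highest of the three numbers, yet its gaps to compound 2 and to compound 1 lie within the scatter, so the three compounds stand level. Compound 4 `Clc1ccc(CO/N=C/c2c(-c3ccc4ccccc4c3)nc3occn23)cc1` differs from compound 3 by chloro in place of trifluoromethyl on an aromatic carbon. Among the compounds with values here, only one measured step touches this part of the molecule: a 1.3-fold higher number from compound 1 to compound 3 (0.10 log units; within the scatter), which stayed within the scatter. The other step, a 1.1-fold higher number from compound 1 to compound 2 (0.04 log units; within the scatter), changes a different position and is also within the scatter. No step beyond the scatter is therefore expected. For compound 4 the estimated step is a 1.0-fold lower number from compound 3 to compound 4 (0.02 log units; within the scatter). Compound 4 is expected to give 450 nM, with a range from 200 nM to 1000 nM.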

Compound 4, half-maximal effective concentration: 990 nM
Estimate against measurement, compound 4: 2.2-fold (0.34 log units) below; low and high end bracket the measured number.
By their numbers in this assay, from the lowest: compounds 1, 2 and 3 (each within the scatter of the next); then compound 4.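

In this assay, within the data shown here, the group on this aromatic carbon does matter: chloro in place of trifluoromethyl gives a 2.1-fold higher number from compound 3 to compound 4 (0.32 log units; beyond the scatter) and so a step beyond the scatter, which the earlier compounds never showed. Hydrogen in place of one chloro gives a 2.7-fold higher number from compound 1 to compound 4 (0.43 log units; beyond the scatter) and is also beyond the scatter, so compound 1 and compound 3 stand level while compound 4 stands apart from both. Nothing available explains this difference.

On these data alone, whether an amine or a carboxylic acid on this carbon would give a higher or lower number remains open. Also open, as far as these compounds go, is whether chloro in place of trifluoromethyl gives a similar step with 4-chlorophenyl in place of naphthalen-2-yl on the core.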